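This account rests on a few compounds, and the source may have more. Where it says the series, first, only, none or still open, it means among the compounds named here.

Measured so far:
compound 1 `CC(=O)OC[C@H]1O[C@@H](n2cc(Cn3cc(C(C)=O)c4ccccc43)nn2)[C@H](OC(C)=O)[C@@H](OC(C)=O)[C@@H]1OC(C)=O` — > 200000 nM (a limit)
compound 2 `CC(=O)OC[C@H]1O[C@@H](n2cc(Cn3cc([N+](=O)[O-])c4ccccc43)nn2)[C@H](OC(C)=O)[C@@H](OC(C)=O)[C@@H]1OC(C)=O` — > 200000 nM (a limit)
compound 3 `CC(=O)OC[C@H]1O[C@@H](n2cc(Cn3cc(/C=C4/C(=O)Nc5ccccc54)c4ccccc43)nn2)[C@H](OC(C)=O)[C@@H](OC(C)=O)[C@@H]1OC(C)=O` — 22200 nM

In a functional assay on MCF7 cells (Homo sapiens) for cytotoxicity, read by sulforhodamine B assay, with a stated time of 48 h (a lower number here means a stronger inhibitor, a higher number a weaker inhibitor), compound 1 reaches only the limit > 200000 nM. Compound 2 likewise sits at the limit > 200000 nM. Going by the values given here, compound 3 gives 22200 nM, the sole finite number in the set. The values of compound 1 and compound 2 are limits, namely (the limit of > 200000 nM in this assay, at which 2 of the 3 values shown sit). The steps of an at least 9.0-fold lower number from compound 1 to compound 3 (0.95 log units; beyond the scatter) and an at least 9.0-fold lower number from compound 2 to compound 3 (0.95 log units; beyond the scatter) both concern the exchange of a small substituent for the large group on the shared core and are readable only as limits.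

Compound 4 `CC(=O)OC[C@H]1O[C@@H](n2cc(Cn3cc(/C=C4/C(=O)Nc5ccc(F)cc54)c4ccccc43)nn2)[C@H](OC(C)=O)[C@@H](OC(C)=O)[C@@H]1OC(C)=O` keeps that large group and differs from compound 3 by fluoro in place of hydrogen on an aromatic carbon. Among the compounds with values here, no measured step covers a change of this kind on that ring. The expected step is a 1.2-fold lower number from compound 3 to compound 4 (0.09 log units; within the scatter), not beyond the scatter. Compound 4 is estimated at 18000 nM, range 7000 nM to 50000 nM.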

Compound 4, half-maximal inhibitory concentration: 40400 nM
The estimate for compound 4 lay 2.2-fold (0.35 log units) below the measured number; the range from low to high includes it.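

Fluoro in place of hydrogen on this aromatic carbon gives a 1.8-fold higher number from compound 3 to compound 4 (0.26 log units; within the scatter), so in this assay this first substitution on that ring does not separate compound 4 from compound 3. With fluoro present, the large group still stands clear of the small substituents: an at least 4.9-fold lower number from compound 2 to compound 4 (0.69 log units; beyond the scatter), and an at least 4.9-fold lower number from compound 1 to compound 4 (0.69 log units; beyond the scatter). Both of these steps start from a limit, not a number: the limit of > 200000 nM in this assay, at which 2 of the 4 values shown sit.

Open, going by these compounds, is whether chloro, methoxy or an amine on the same aromatic carbon would give a step beyond the scatter. Also open is whether any change on this ring moves the number at all, since a single substituent is shown there.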